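Taking the chloro group off compound 3

The source may hold more compounds than are shown below. What is called first, only, known or untested is meant among the compounds shown, and "the series" means these compounds.

For the measured compounds named here, in an ADME assay on MT4 cells (Homo sapiens) for cytotoxicity, read by MTT assay, with a stated time of 4 days (a lower number here means that less compound is tolerated, a higher number that more compound is tolerated), compound 3 `N#Cc1ccc(Nc2nc(Oc3ccc(Cl)cc3)c3ccccc3n2)cc1` gives 198000 nM, the only true number so far. Compound 1 `N#Cc1ccc(Nc2nc(Oc3ccc(F)cc3)c3ccccc3n2)cc1` gives > 351000 nM, which is a limit of the assay. Compound 2 `COc1cc(C#N)ccc1Oc1nc(Nc2ccc(C#N)cc2)nc2ccccc12` gives >= 140000 nM, also a limit. Compound 4 `N#Cc1ccc(Nc2nc(Oc3ccccc3)c3ccccc3n2)cc1` is not yet measured: hydrogen in place of chloro on an aromatic carbon, with hydrogen in place of chloro, para to a large group. Going by the values given here, the one readable step that bears on this also involves the chloro group: an at least 1.7-fold lower number from compound 1 to compound 3 (0.24 log units; that floor lies within the scatter). The other step into compound 3 tells nothing about size: a step that the limit leaves unreadable from compound 2 to compound 3. A small move towards more tolerated compound is therefore expected, a 1.3-fold higher number from compound 3 to compound 4 (0.12 log units; within the scatter), possibly no more than scatter. Compound 4 is estimated at 260000 nM, with an expected range of 130000 nM to 500000 nM.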

Compound 4, half-maximal cytotoxic concentration: 370000 nM
Beside the measured number, compound 4's estimate is 1.4-fold (0.15 log units) below it, and the stated range covers the measured number.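

For the compounds shown here, replacing the chloro group with hydrogen, para to a large group, gives the first step at this position with true numbers at both ends in this assay: a 1.9-fold higher number from compound 3 to compound 4 (0.27 log units; within the scatter). Compound 3 and compound 4 therefore show no difference beyond the scatter, whereas the earlier step gave only a floor. The steps from compound 1 and compound 2 to compound 4 cannot be read, as each starts from a limit of the assay.

Going by these compounds, whether an amine or a carboxylic acid in this place would move the number beyond the scatter stays open. On these data alone, how fluoro compares with hydrogen here stays open too.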